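A few compounds are considered here, and "the series" means these few. Any claim that something is new, unique, unknown or untested is made for them only; others in the source may bear on it.

Values in a functional assay on K562 cells (Homo sapiens) for cytotoxicity, read by trypan blue exclusion, with a stated time of 96 h; a higher number here means a weaker inhibitor, a lower number a stronger inhibitor:
- compound 1 `COc1cc(OC)c(/C=C/S(=O)(=O)Nc2ccc(OC)c([N+](=O)[O-])c2)c(OC)c1`: 1000 nM
- compound 2 `COC(=O)C(C)(C)Nc1cc(NS(=O)(=O)/C=C/c2c(OC)cc(OC)cc2OC)ccc1OC`: 300 nM
- compound 3 `COc1cc(OC)c(/C=C/S(=O)(=O)Nc2ccc(OC)c(NCC(=O)O)c2)c(OC)c1`: 20 nM

Compound 3 has the lowest number of the three, and its gaps to both others lie beyond the scatter. Compound 4 `COc1cc(OC)c(/C=C/S(=O)(=O)Nc2ccc(OC)c(NC(C)(C)C(=O)O)c2)c(OC)c1` has 1-carboxy-1-methylethyl in place of carboxymethyl on a nitrogen on an aromatic ring. Going by the values given here, no measured step isolates this change. The closest is a 15-fold lower number from compound 2 to compound 3 (1.18 log units; beyond the scatter), which combines it with a change from methoxycarbonyl to carboxy. The steps of a 3.3-fold lower number from compound 1 to compound 2 (0.52 log units; beyond the scatter) and a 50-fold lower number from compound 1 to compound 3 (1.70 log units; beyond the scatter) both replace nitro and bear on it only indirectly. A moderate rise is therefore expected in this assay, covering part of the gap between compound 3 and compound 2. For compound 4 the estimate is 50 nM, with an expected range of 15 nM to 250 nM. The estimated step is a 2.5-fold higher number from compound 3 to compound 4 (0.40 log units; beyond the scatter).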

Compound 4, half-maximal inhibitory concentration: 5 nM
Compound 4: middle estimate off by 10-fold (1.00 log units), on the high side, outside the stated range (below it).
By their numbers in this assay, from the lowest: compound 4; then compound 3; then compound 2; then compound 1.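

On a nitrogen on an aromatic ring, 1-carboxy-1-methylethyl in place of carboxymethyl gives a 4.0-fold lower number from compound 3 to compound 4 (0.60 log units; beyond the scatter) in this assay, so the branched acid chain is the better of the two here. Hydrogen in place of methyl on an oxygen next to a carbonyl group, earlier seen only together with a chain change, now stands alone as a 60-fold lower number from compound 2 to compound 4 (1.78 log units; beyond the scatter), and replacing nitro with the branched acid gives a 200-fold lower number from compound 1 to compound 4 (2.30 log units; beyond the scatter). No evidence is available to explain these steps. Still open, from the compounds shown here alone, is how a single methyl on the chain would compare, and whether a primary amide or a longer chain could stand in for the carboxylic acid.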